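A few compounds are considered here, and "the series" means these few. Any claim that something is new, unique, unknown or untested is made for them only; others in the source may bear on it.

Working notes on the series. The shared core of compound 1 `CN1CCN(c2ccc(Nc3ncc4nc(Nc5ccc(F)cc5)n([C@H]5CCNC5)c4n3)cc2)CC1` carries a piperidin-3-yl group on an aromatic nitrogen in compound 3 `CN1CCN(c2ccc(Nc3ncc4nc(Nc5ccc(F)cc5)n([C@@H]5CCCNC5)c4n3)cc2)CC1`; in a functional assay on NCI-H1975 cells (Homo sapiens) for antiproliferative activity, read by MTT assay, with a stated time of 72 h (a higher number here means a weaker inhibitor, a lower number a stronger inhibitor), compound 1 gives "not determined" (no result reported) and compound 3 gives "not determined" (no result reported), so compound 3 has no standing of its own on the measured values. Among the compounds with values here, compound 2 `CN1CCN(c2ccc(Nc3ncc4nc(Nc5ccc(F)cc5)n([C@H]5CCCN(S(=O)(=O)C6CC6)C5)c4n3)cc2)CC1` is the only member with a result in this assay, where compound 2 gives 1150 nM. Compound 4 `CN1CCN(c2ccc(Nc3ncc4nc(Nc5ccc(F)cc5)n([C@@H]5CCN(S(=O)(=O)C6CC6)C5)c4n3)cc2)CC1` differs from compound 3 by 1-(cyclopropylsulfonyl)pyrrolidin-3-yl in place of piperidin-3-yl on an aromatic nitrogen. Within the data shown here, no step between two measured compounds is available for this change, so its size and direction in this assay cannot be read from the data; with only compound 2 in hand, the expectation is that compound 4 lands near where compound 2 stands, with no step beyond the scatter anticipated in either direction, but with wide uncertainty. Compound 4 is estimated at 1200 nM in this assay, within a range from 300 nM to 5000 nM.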

Compound 4, half-maximal inhibitory concentration: > 10000 nM
Compound 4 was reported as a limit (the forecaster's own chance of this, stated with the estimate: 10%); middle value at least 8.3-fold (0.92 log units) from the limit.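

In this assay, 1-(cyclopropylsulfonyl)pyrrolidin-3-yl in place of 1-(cyclopropylsulfonyl)piperidin-3-yl on an aromatic nitrogen gives an at least 8.6-fold higher number from compound 2 to compound 4 (0.93 log units; beyond the scatter). Within the data shown here, this is the first readable step at this position, and it shows that the read-out here depends on the ring carrying the cyclopropylsulfonyl group, not on that group alone. Compound 4 is reported as a limit and not a number, so the step fixes only a lower bound on the size of the change: the limit of > 10000 nM in this assay, at which 1 of the 4 values shown sits.

Steps involving compound 1 and compound 3 cannot be read, so what the cyclopropylsulfonyl group contributes on either ring remains open. Also open, from the compounds shown here alone, is whether an acetyl or a methylsulfonyl group on the ring nitrogen would follow the same dependence on ring size.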